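This account rests on a few compounds, and the source may have more. Where it says the series, first, only, none or still open, it means among the compounds named here.

The three measured compounds, compound 1 (`COc1cc([C@](O)(CCN(C)C)[C@@H](c2cc3cc(Br)ccc3nc2OC)c2cccc(OC)c2F)cc(OC(C)C)n1`), compound 2 (`COc1cc([C@](O)(CCN(C)C)[C@@H](c2cc3cc(Br)ccc3nc2OC)c2ccnc(OC)c2OC)cc(OC(C)C)n1`) and compound 3 (`CCCOc1cc([C@](O)(CCN(C)C)[C@@H](c2cc3cc(Br)ccc3nc2OC)c2ccnc(OC)c2OC)cc(OC)n1`), share one core. In an ADME assay on the whole organism (Mus musculus, strain CD-1) for pharmacokinetics (a higher number here means faster removal of the compound, a lower number slower removal), compound 1 gives 8.9 mL/min/kg, compound 2 gives 6.8 mL/min/kg and compound 3 gives 6.9 mL/min/kg. Compound 1 therefore stands level with the other two, all three lying within the scatter of one another.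

Compound 4 (`COc1cccc([C@H](c2cc3cc(Br)ccc3nc2OC)[C@@](O)(CCN(C)C)c2cc(SC)nc(SC)c2)c1F`) departs from compound 1 in one place: a group of 10 heavy atoms (7 carbon, 1 nitrogen, 2 sulfur; one six-membered aromatic ring with 1 hetero atom) in place of a group of 12 heavy atoms (9 carbon, 1 nitrogen, 2 oxygen; one six-membered aromatic ring with 1 hetero atom), on a saturated chain carbon bound to an oxygen on a saturated carbon and two saturated chain carbons. Among the compounds with values here, the entering group brings sulfur, which no measured compound contains.

Within the data shown here, two measured steps bear on this change. The nearer is a 1.0-fold higher number from compound 2 to compound 3 (0.01 log units; within the scatter), with propyl in place of isopropyl on an oxygen on an aromatic ring, a small edit within the very group that leaves here. The other is a 1.3-fold lower number from compound 1 to compound 2 (0.12 log units; within the scatter), with 2,3-dimethoxypyridin-4-yl in place of 2-fluoro-3-methoxyphenyl, made elsewhere on the molecule. Both lie within the scatter, yet neither tests sulfur, and the change here is larger than either, so the evidence is thin and gives no direction. No shift beyond the scatter is expected, and the expected step is a 1.0-fold higher number from compound 1 to compound 4 (0.00 log units; within the scatter). For compound 4 the estimated clearance is 9 mL/min/kg, with an expected range from 4.5 mL/min/kg to 18 mL/min/kg.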

Compound 4, clearance: 13 mL/min/kg
Compound 4: middle estimate off by 1.4-fold (0.16 log units), on the low side; the range from low to high includes it.
By their numbers in this assay, from the lowest: compounds 2, 3, 1 and 4 (each within the scatter of the next).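

In this assay the whole group on the saturated chain carbon bound to an oxygen on a saturated carbon and two saturated chain carbons was exchanged, giving a 1.5-fold higher number from compound 1 to compound 4 (0.16 log units; within the scatter) and showing that this position can take a much larger edit than the propyl for isopropyl swap seen earlier without leaving the scatter. Compound 4 is also the only compound shown that carries sulfur, and in this one pair the exchange of the two oxygens for two sulfurs, with the loss of two carbons, moves clearance no further than repeat measurements would. No measurement shown explains this step.

Both sulfurs enter together, so the compounds shown cannot tell what either contributes alone, and a ring bearing one methylthio group and one methoxy group would separate the two. As far as these compounds go, it also remains open whether the step holds with the 2,3-dimethoxypyridin-4-yl group of compound 2 in place of 2-fluoro-3-methoxyphenyl, and how this position would respond to an amine or a longer chain on the ring.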